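This account rests on a few compounds, and the source may have more. Where it says the series, first, only, none or still open, it means among the compounds named here.

In a functional assay on OVCAR-4 cells (Homo sapiens) for cytotoxicity, read by sulforhodamine B assay, with a stated time of 48 h, tested at 10 uM (a lower number here means a stronger effect, a higher number a weaker effect of the compound at the concentration tested), compound 1 `COc1cc(-c2cc(/C=C/C(=O)c3ccc(N)cc3)[nH]n2)cc(OC)c1OC` gives -22%, the second highest of the three measured numbers. Compound 2 `COc1ccc(-c2cc(/C=C/C(=O)c3ccc(OC)c(OC)c3)[nH]n2)cc1` gives -27%, within the scatter of compound 1, while compound 3 `COc1ccc(-c2cc(/C=C/C(=O)c3ccc(N)cc3)[nH]n2)cc1OC` gives 24%, and the step of a number 46 percentage points higher from compound 1 to compound 3 (beyond the scatter) lies beyond the scatter. Compound 4 `COc1ccc(C(=O)/C=C/c2cc(-c3cc(OC)c(OC)c(OC)c3)n[nH]2)cc1OC` is not yet measured. It differs from compound 1 in one place: 3,4-dimethoxyphenyl in place of 4-aminophenyl on a carbonyl carbon. Going by the values given here, no measured step covers this change; the only known step alters a different ring, and compounds 2 and 3, which differ in two places, only show both groups on the carbonyl carbon yielding values on either side of zero. A step of a number 2 percentage points higher from compound 1 to compound 4 (within the scatter) is therefore expected, not beyond the scatter. Compound 4 is estimated at -20%, ranging from -45% to 10%.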

Compound 4, a percentage reported as activity, at one concentration (the size of the read-out at that concentration, not a potency): 23%
Estimate against measurement, compound 4: 43 percentage points below; the whole stated range lies below it.
By their numbers in this assay, from the lowest: compounds 2 and 1 (each within the scatter of the next); then compounds 4 and 3 (each within the scatter of the next).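

On the carbonyl carbon, the group matters: in this assay, 3,4-dimethoxyphenyl in place of 4-aminophenyl gives a number 45 percentage points higher from compound 1 to compound 4 (beyond the scatter), meaning a much weaker effect at the concentration tested. Changing this part of the molecule alone is therefore enough to lose the effect seen for compound 1. Nothing measured here explains this step.

As far as these compounds go, it remains open whether the step reflects losing the amine or gaining the methoxy groups. A plain phenyl group on the carbonyl carbon would help separate the two.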